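The compounds below may be only part of what the source reports. "The series", "measured", "known", "first", "only" and "open" are said of these compounds alone.

Compound 1 `Cc1ccc2[nH]c(=O)c(CN(Cc3ccccc3)Cc3ccc(C(C)(C)C)cc3)cc2c1`: in a toxicity assay on MDCK cells (Canis lupus familiaris) for cytotoxicity, read by crystal violet staining, with a stated time of 48 h (on this read-out higher numbers stand for lower toxicity in this test and lower numbers for higher toxicity in this test), compound 1 gives only a limit, > 5000 nM.
Compound 2 `Cc1ccc2[nH]c(=O)c(CN(Cc3ccc(F)cc3)Cc3ccc(C(C)(C)C)cc3)cc2c1`: compound 2 gives only a limit, > 27000 nM.
Compound 3 `Cc1ccc2[nH]c(=O)c(CN(Cc3ccc(OCC(=O)OC(C)(C)C)cc3)Cc3ccc(C(C)(C)C)cc3)cc2c1`: compound 3 gives only a limit, > 10000 nM.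

Compound 3 therefore stands at a limit in this assay (the limit of > 10000 nM in this assay, at which 1 of the 3 values shown sits), with no number to place it. Compound 1 sits at a limit as well (the limit of > 5000 nM in this assay, at which 1 of the 3 values shown sits). Compound 2 likewise sits at a limit (the limit of > 27000 nM in this assay, at which 1 of the 3 values shown sits). Compound 4 `COc1ccc(CN(Cc2ccc(C(C)(C)C)cc2)Cc2cc3cc(C)ccc3[nH]c2=O)cc1` differs from compound 3 by hydrogen in place of tert-butoxycarbonyl on a saturated chain carbon bound to an oxygen on an aromatic ring. The steps touching the same group, a step that the two limits leave unreadable from compound 1 to compound 3 and a step that the two limits leave unreadable from compound 2 to compound 3, cannot be read in size, and neither can a step that the two limits leave unreadable from compound 1 to compound 2. With nothing readable among these three compounds, no step beyond the scatter is expected, so the step that the limit leaves unreadable from compound 3 to compound 4 is estimated as none in this assay. Compound 4 is expected to give about 20000 nM, in the range 5000 nM to 80000 nM.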

Compound 4, half-maximal cytotoxic concentration: > 10000 nM
Compound 4 ended at the assay's limit (the forecaster's own chance of this, stated with the estimate: 70%); the middle value lies beyond the limit too.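

In this assay, going by these compounds alone, compound 4 gives only a limit, > 10000 nM, so no step linking it to compound 1, compound 2 or compound 3 can be read. The compounds shown leave open whether any of these changes alters the half-maximal cytotoxic concentration at all.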